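The compounds below may be only part of what the source reports. "The series", "measured", "known", "first", "only" and "open" are said of these compounds alone.

Measured compounds:
- compound 1, `Nc1scc(CN2CCN(c3cccnc3)CC2)c1C(=O)c1ccc(Cl)cc1`, -2.7%
- compound 2, `Nc1scc(CN2CCN(c3ccc(C(F)(F)F)cc3)CC2)c1C(=O)c1cccc(C(F)(F)F)c1`, -27%
- compound 3, `Nc1scc(CN2CCN(c3cccc(F)c3)CC2)c1C(=O)c1cccc(C(F)(F)F)c1`, -35%

All three were tested in a functional assay on CHO cells with adenosine receptor A1 (Homo sapiens) as the target, read by cAMP accumulation and immunoassay, with a stated time of 6 min, tested at 1 uM; a higher number here means a weaker effect of the compound at the concentration tested, a lower number a stronger effect. Compound 1 gives the highest number of the three; compound 2 lies below it by more than the usual scatter, and compound 3 lies further below still. Among the compounds with values here, the one single-point change among the measured compounds, a number 8 percentage points lower from compound 2 to compound 3 (within the scatter), swaps one aryl group for another on the ring nitrogen and stays within the scatter.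

Compound 4, `Nc1scc(CN2CCN(c3c(F)cc(F)cc3F)CC2)c1C(=O)c1ccc(Cl)cc1`, has not yet been measured in this assay. It differs from compound 1 in one place: 2,4,6-trifluorophenyl in place of pyridin-3-yl on an amine nitrogen in a ring. Within the data shown here, no measured step changes the pyridinyl group at this position, so nothing bears directly on this step. Compounds 2 and 3, which carry carbon-only aryl groups on the ring nitrogen, give lower numbers than compound 1, but they also differ elsewhere, so that gap cannot be assigned to the ring-nitrogen group alone. A modest step downward is therefore expected, a number 12.3 percentage points lower from compound 1 to compound 4 (beyond the scatter), with wide uncertainty. Compound 4 is estimated to give -15%, between -40% and 10%.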

Compound 4, a percentage reported as activity, at one concentration (the size of the read-out at that concentration, not a potency): -56%
Estimate against measurement, compound 4: 41 percentage points above; measured number outside the range, below it.
By their numbers in this assay, from the lowest: compound 4; then compounds 3 and 2 (each within the scatter of the next); then compound 1.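

In this assay, within the data shown here, changing only the group on the amine nitrogen in the ring gives a number 53.3 percentage points lower from compound 1 to compound 4 (beyond the scatter), whereas the only earlier single-place step was a number 8 percentage points lower from compound 2 to compound 3 (within the scatter), so this is the first sign that this position alone can move the read-out strongly. The change swaps pyridin-3-yl, which has a ring nitrogen and a hydrogen-bond acceptor, for 2,4,6-trifluorophenyl, which is carbon-only with fluorine added, so several features change in a single step. Nothing available here explains the size of this step.

A plain phenyl group on the same nitrogen would help separate the loss of the pyridine nitrogen from the gain of fluorine. Going by these compounds, whether a single fluorine, or a methoxy group, would do the same on this shared core remains open.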